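Methoxyphenyl in Place of Methylphenyl: An Expected Partition Coefficient

A few compounds are considered here, and "the series" means these few. Any claim that something is new, unique, unknown or untested is made for them only; others in the source may bear on it.

Measured compounds:
compound 1 `O=Cc1ccc(-c2cn3ccnc3c(-c3ccc4ncn(C5CCCCC5)c4c3)n2)cc1`, 1.5
compound 2 `Fc1ccc(-c2cn3ccnc3c(-c3ccc4ncn(C5CCCCC5)c4c3)n2)cc1`, 2.01
compound 3 `Cc1cccc(-c2cn3ccnc3c(-c3ccc4ncn(C5CCCCC5)c4c3)n2)c1`, 1.87

In a physicochemical assay for lipophilicity, using the shake flask method, in phosphate buffer, measured as octanol-water partition, with a stated time of 85 min, at pH 7.4 (a higher number here means a more lipophilic compound, a lower number a more polar compound), compound 3 stands second highest of the three. Its nearest neighbour is compound 2, with a number 0.14 log units lower from compound 2 to compound 3 (within the scatter); its furthest is compound 1, with a number 0.37 log units higher from compound 1 to compound 3 (beyond the scatter). Compound 4 `COc1ccccc1-c1cn2ccnc2c(-c2ccc3ncn(C4CCCCC4)c3c2)n1` differs from compound 3 by 2-methoxyphenyl in place of 3-methylphenyl on an aromatic carbon. For the measured compounds named here, no measured step involves a methoxy group, so none bears on this change directly. The steps of a number 0.51 log units higher from compound 1 to compound 2 (beyond the scatter) and a number 0.37 log units higher from compound 1 to compound 3 (beyond the scatter) were modest, and the exchange of substituted phenyl rings between compound 2 and compound 3 stayed within the scatter. A modest downward step is therefore expected, a number 0.37 log units lower from compound 3 to compound 4 (beyond the scatter). For compound 4 the estimated value in this assay is 1.5, within a range of 1.1 to 1.9.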

Compound 4, partition coefficient: 1.72
For compound 4 the middle estimate is 0.22 log units below the measured one; measured number inside the range.
By their numbers in this assay, from the lowest: compounds 1, 4, 3 and 2 (each within the scatter of the next, the first and the last beyond it).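

In this assay, 2-methoxyphenyl, which brings an oxygen and a hydrogen-bond acceptor, gives a step within the scatter from 3-methylphenyl, a number 0.15 log units lower from compound 3 to compound 4 (within the scatter). For the compounds shown here, the same holds against the other two rings, a number 0.29 log units lower from compound 2 to compound 4 (within the scatter) and a number 0.22 log units higher from compound 1 to compound 4 (within the scatter), so compound 4 is the first compound here within the scatter of every other, although compound 1 and compound 2 remain beyond it of each other. No measurement offers an explanation for this result.

From the compounds shown here alone, how a phenyl ring bearing an amine or a carboxylic acid would stand in this assay remains open. Also open, going by these compounds, is a comparison of methoxy with methyl at one ring position, which compound 3 and compound 4, as 3-methylphenyl and 2-methoxyphenyl, do not give.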